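Loss of the Carbamoyl Group and Cytotoxicity in HEL Cells

This account rests on a few compounds, and the source may have more. Where it says the series, first, only, none or still open, it means among the compounds named here.

Measured compounds:
compound 1, `CCOC(=O)NC(=O)NC1=CS(=O)(=O)O[C@@]12[C@@H](CO[Si](C)(C)C(C)(C)C)O[C@@H](n1cc(C)c(=O)n(C)c1=O)[C@@H]2O[Si](C)(C)C(C)(C)C`, 16000 nM
compound 2, `C=C(C)C(=O)NC(=O)NC1=CS(=O)(=O)O[C@@]12[C@@H](CO[Si](C)(C)C(C)(C)C)O[C@@H](n1cc(C)c(=O)n(C)c1=O)[C@@H]2O[Si](C)(C)C(C)(C)C`, 20000 nM
compound 3, `COC(=O)C(=O)CNC1=CS(=O)(=O)O[C@@]12[C@@H](CO[Si](C)(C)C(C)(C)C)O[C@@H](n1cc(C)c(=O)n(C)c1=O)[C@@H]2O[Si](C)(C)C(C)(C)C`, a limit of > 400000 nM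

In a functional assay on HEL cells (Homo sapiens) for cytotoxicity, read by microscopy (on this read-out higher numbers stand for lower toxicity in this test and lower numbers for higher toxicity in this test), compound 1 gives 16000 nM, the lowest of the two numbers that are actual values; compound 2 lies nearest to it, and a 1.3-fold higher number from compound 1 to compound 2 (0.10 log units; within the scatter). Compound 3 reaches only a limit in this assay, > 400000 nM, and this limit is the limit of > 400000 nM in this assay, at which 1 of the 3 values shown sits. Compound 4, `Cc1cn([C@@H]2O[C@H](CO[Si](C)(C)C(C)(C)C)[C@@]3(OS(=O)(=O)C=C3NCCC(=O)O)[C@H]2O[Si](C)(C)C(C)(C)C)c(=O)n(C)c1=O`, has not yet been measured; it differs from compound 1 in one place: 2-carboxyethyl in place of (ethoxycarbonyl)carbamoyl on an amine nitrogen.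

For the measured compounds named here, the steps that bear on this change are those in which the (ethoxycarbonyl)carbamoyl group, or the ((1-methylethenyl)carbonyl)carbamoyl group, is removed from the amine nitrogen: an at least 25-fold higher number from compound 1 to compound 3 (1.39 log units; beyond the scatter), and an at least 20-fold higher number from compound 2 to compound 3 (1.30 log units; beyond the scatter). Both are large and in the same direction. Compound 4 also loses the carbamoyl group on the amine nitrogen, so a large upward step in this assay is expected, a 13-fold higher number from compound 1 to compound 4 (1.10 log units; beyond the scatter). Compound 4 is therefore estimated at 200000 nM, between 40000 nM and 400000 nM, with a fair chance that only a limit is reported.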

Compound 4, minimum cytotoxic concentration: 80000 nM
Beside the measured number, compound 4's estimate is 2.5-fold (0.40 log units) above it, and the stated range covers the measured number.
By their numbers in this assay, from the lowest: compounds 1 and 2 (each within the scatter of the next); then compound 4. At a limit, above all of these: compound 3.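

In this assay, the loss of the carbamoyl group from the amine nitrogen does not carry a compound to the limit of the test: 2-carboxyethyl in place of (ethoxycarbonyl)carbamoyl gives a 5.0-fold higher number from compound 1 to compound 4 (0.70 log units; beyond the scatter), and in place of ((1-methylethenyl)carbonyl)carbamoyl it gives a 4.0-fold higher number from compound 2 to compound 4 (0.60 log units; beyond the scatter). The group that replaces the carbamoyl therefore still counts, as carboxymethyl in place of (methoxycarbonyl)carbonyl on the saturated chain carbon gives an at least 5.0-fold lower number from compound 3 to compound 4 (0.69 log units; beyond the scatter). Compound 3 is read only as a limit, not as a number: the limit of > 400000 nM in this assay, at which 1 of the 4 values shown sits.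

The compounds shown leave open whether the carboxylic acid of compound 4 or the length of its chain sets this result; a methyl ester on the same chain, a 3-carboxypropyl chain or a 2-aminoethyl group would separate these. They also leave open how an unsubstituted amine at this position would read.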